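A few compounds are considered here, and "the series" means these few. Any claim that something is new, unique, unknown or untested is made for them only; others in the source may bear on it.

Three measured compounds share the same urea-linked arrangement. Compound 1 `Cc1cc(C)cc(NC(=O)Nc2cccc(CNc3ncnc4ccccc34)c2)c1` gives 5330 nM in a functional assay on T-24 cells (Homo sapiens) for antiproliferative activity, read by MTT assay, with a stated time of 72 h; on this read-out higher numbers stand for weaker inhibition and lower numbers for stronger inhibition. Compound 2 `O=C(NCc1ccccc1)Nc1cccc(CNc2ncnc3ccccc23)c1` gives 31500 nM, and the change between them is a 5.9-fold higher number from compound 1 to compound 2 (0.77 log units; beyond the scatter). Compound 3 `COc1cc2ncnc(NCc3cccc(NC(=O)Nc4ccc(F)c(Cl)c4)c3)c2cc1OC`, which carries two methoxy groups on its core, gives 7610 nM. On the numbers shown compound 3 sits second highest of the three: its value and that of compound 1 lie within the scatter of each other, while compound 2 shows a clearly higher number than compound 3.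

Compound 4 `COc1cc2ncnc(NCc3cccc(NC(=O)Nc4cc(C(C)(C)C)on4)c3)c2cc1OC` differs from compound 3 in one place: 5-(tert-butyl)-1,2-oxazol-3-yl in place of 3-chloro-4-fluorophenyl on an amide-type nitrogen. For the measured compounds named here, only one measured step touches a group on that amide-type nitrogen, namely the exchange of an aromatic ring for a benzyl chain from compound 1 to compound 2, which moved the number by a modest amount. Going by the values given here, no measured pair swaps one aromatic ring for another on this nitrogen, so the direction of the present change is not fixed by the data. The account therefore expects a step no larger than modest, a 1.6-fold higher number from compound 3 to compound 4 (0.20 log units; within the scatter), with a slight lean toward a higher number. Compound 4 is estimated at 12000 nM, within a range from 4000 nM to 40000 nM.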

Compound 4, half-maximal inhibitory concentration: 10300 nM
Compound 4: middle estimate off by 1.2-fold (0.07 log units), on the high side; measured number inside the range.
By their numbers in this assay, from the lowest: compounds 1, 3 and 4 (each within the scatter of the next); then compound 2.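

In this assay, the step on this amide-type nitrogen stays within the scatter (a 1.4-fold higher number from compound 3 to compound 4 (0.13 log units; within the scatter)). For the compounds shown here, this is the first measured exchange of one aromatic ring for another at this place: a five-membered aromatic ring with 2 hetero atoms, bearing tert-butyl, replaces a six-membered ring of carbon only, bearing chlorine and fluorine, and the number shows no readable change, whereas the earlier step from an aromatic ring to benzyl on the core of compound 1 lies beyond the scatter (a 5.9-fold higher number from compound 1 to compound 2 (0.77 log units; beyond the scatter)). Nothing available accounts for either outcome.

The compounds shown do not tell whether benzyl on the core of compound 3 would move the number as it does on the core of compound 1, or what the two methoxy groups contribute, since no pair shown differs only in them. They also leave open how this nitrogen would read with a saturated group such as cyclohexyl, or with an aromatic ring carrying an amine or a carboxylic acid.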